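Trimming the Ring Amine Substituent of a Nitrile Inhibitor

The source may report more compounds than this note shows. Statements on the series, on what has been measured and on what is new or still open speak of the compounds shown alone.

Of the compounds shown here, three have so far been measured in an assay on isolated protein for inhibition of cathepsin S (Homo sapiens); on this read-out lower numbers stand for stronger inhibition and higher numbers for weaker inhibition. Compound 1 `CC1CCC(C[C@H](CC(=O)N2CCOCC2)C(=O)N[C@]2(C#N)CCN(C3CCCCC3)C2)CC1` gives 14 nM, compound 2 `N#C[C@@]1(NC(=O)[C@@H](CC(=O)N2CCOCC2)CC2CCCCC2)CCN(C2CCCC2)C1` gives 75 nM, and compound 3 `N#C[C@H](CCc1ccccc1)NC(=O)[C@@H](CC(=O)N1CCOCC1)CC1CCCCC1` gives 171 nM. Compound 2 therefore holds the second highest of the three numbers: its nearest neighbour is compound 3, whose number is higher by a gap beyond the scatter, while compound 1 stands furthest away, with a lower number by a gap that is also beyond the scatter.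

Compound 4 `CC(C)N1CC[C@@](C#N)(NC(=O)[C@@H](CC(=O)N2CCOCC2)CC2CCCCC2)C1` has not yet been measured. It differs from compound 2 in one place (isopropyl in place of cyclopentyl on an amine nitrogen in a ring). Among the measured compounds shown here, no measured pair shows this particular change, so no directly comparable step is available, and the three measured compounds all differ from one another in more than one place. The change removes a ring and shortens the group on the amine nitrogen in the ring, and the expectation here is a modest step toward a higher number, probably just beyond the scatter rather than a large shift.

Compound 4 is thus expected to give about 150 nM, within a range from 60 nM to 400 nM. The expected step of a 2.0-fold higher number from compound 2 to compound 4 (0.30 log units; within the scatter) corresponds to a mild weakening of inhibition.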

Compound 4, half-maximal inhibitory concentration: 66 nM
Compound 4: the middle estimate sits 2.3-fold (0.36 log units) above what was measured, within the range that was stated.
By their numbers in this assay, from the lowest: compound 1; then compounds 4 and 2 (each within the scatter of the next); then compound 3.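

In this assay, replacing cyclopentyl with isopropyl on the amine nitrogen in a ring gives a 1.1-fold lower number from compound 2 to compound 4 (0.06 log units; within the scatter). Among the compounds shown here, this is the first pair among the compounds that differs in one place, and it shows that at this position, two ring bonds from the ring atom that bears a cyano group, the five-membered carbon ring can give way to an open branched group with no change that this read-out can resolve. Nothing on hand bears on why the two compounds read alike.

For the compounds shown here, this single step covers only two plain carbon groups, so it cannot show how far the same position accepts other kinds of substituent, and one pair is not enough to call the position insensitive in general. Still open, from the compounds shown here alone, is what a methyl group, a phenyl ring, or a longer chain ending in an amine or a carboxylic acid would do on the same nitrogen, with the rest of compound 4 held fixed.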